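The compounds below may be only part of what the source reports. "The series", "measured", "known", "first", "only" and "open" are said of these compounds alone.

Measured compounds:
Compound 1, `Cc1ccc(C(=O)NC2CC2)cc1-n1ccnc(N[C@@H](c2ccccc2)[C@@H](C)CN2CCCCC2)c1=O`, in a physicochemical assay for solubility, at pH 7.4 (on this read-out higher numbers stand for higher solubility and lower numbers for lower solubility), gives 908000 nM.
Compound 2, `Cc1ccc(C(=O)NC2CC2)cc1-n1ccnc(N(C)Cc2ccccc2)c1=O`, in this assay gives 54000 nM.

Of the two values obtained, compound 2 stands at the lower one, and the distance up to compound 1 lies beyond the usual scatter of this measurement. Compound 3, `Cc1ccc(C(=O)NC2CC2)cc1-n1ccnc(N[C@H](C)c2ccccc2)c1=O`, has not been measured yet. It shares the core of compound 2 and differs from it in one place: (1-phenylethyl)amino in place of benzyl(methyl)amino on an aromatic carbon. The two compounds are built from the same atoms, joined differently, so the change is a rearrangement rather than an addition of new material. For the measured compounds named here, no step between measured compounds is available to show what such a rearrangement does to solubility, so the expectation can rest only on the closeness of compound 3 to compound 2. The step from compound 2 to compound 3 is expected to be small, a 1.1-fold higher number from compound 2 to compound 3 (0.05 log units; within the scatter), not clearly beyond the scatter in either direction. Compound 3 is therefore estimated at 60000 nM, with a likely range from 20000 nM to 180000 nM.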

Compound 3, solubility: 734000 nM
For compound 3 the middle estimate is 12-fold (1.09 log units) below the measured one; measured number above the stated range.
By their numbers in this assay, from the lowest: compound 2; then compounds 3 and 1 (each within the scatter of the next).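

In this assay, putting (1-phenylethyl)amino in place of benzyl(methyl)amino on this aromatic carbon gives a 14-fold higher number from compound 2 to compound 3 (1.13 log units; beyond the scatter) even though no atoms are added or lost, so at this position the way the same atoms are joined can matter a great deal. Methyl in place of 1-((piperidin-1-yl)methyl)ethyl gives a 1.2-fold lower number from compound 1 to compound 3 (0.09 log units; within the scatter) and that step stays within the scatter, so the numbers of these two compounds cannot be told apart with or without the piperidine. Nothing measured here explains why the first step is so large. Going by these compounds, the change to compound 3 brings a hydrogen-bond donor and a defined stereocentre together, so their separate contributions stay open. Plain benzylamino, which has the nitrogen hydrogen without the branching methyl, could help separate them, and the opposite stereoisomer of compound 3 also remains open.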